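From Benzyloxy to 2-Cyclohexylethoxy: an Expected Return of Potency

The compounds below may be only part of what the source reports. "The series", "measured", "known", "first", "only" and "open" are said of these compounds alone.

Of the compounds shown here, three have been measured in a functional assay on HCT-15 cells (Homo sapiens) for antiproliferative activity, read by sulforhodamine B assay; a higher number here means a weaker inhibitor of growth, a lower number a stronger inhibitor of growth.
Compound 1, `CC(C)=CCOc1cccc(O)c1C(=O)/C=C/c1ccc(O)cc1`, gives only a limit of the assay, > 30000 nM.
Compound 2, `O=C(/C=C/c1ccc(O)cc1)c1c(O)cccc1OCCC1CCCC1`, gives 3310 nM.
Compound 3, `O=C(/C=C/c1ccc(O)cc1)c1c(O)cccc1OCc1ccccc1`, likewise gives only a limit, > 30000 nM.

Compound 3 therefore stands at the upper edge of what this assay reports, together with compound 1, as noted by the limit of > 30000 nM in this assay, at which 2 of the 3 values shown sit. Only compound 2 sits at a readable number. The change to compound 4, `O=C(/C=C/c1ccc(O)cc1)c1c(O)cccc1OCCC1CCCCC1`, is cyclohexylmethyl in place of phenyl on a saturated chain carbon bound to an oxygen on an aromatic ring. The measured step that bears most directly on it is the reverse one, an at least 9.0-fold higher number from compound 2 to compound 3 (0.95 log units; beyond the scatter), in which the cyclopentylmethyl group gave way to phenyl and the number rose out of range. Compound 4 carries cyclohexylmethyl, which is close in kind to the cyclopentylmethyl of compound 2, and the step of an at least 9.0-fold lower number from compound 1 to compound 2 (0.95 log units; beyond the scatter) shows that such a saturated group on this chain carbon brings the number well below the limit. For compound 4 the expected step is an at least 10-fold lower number from compound 3 to compound 4 (1.00 log units; beyond the scatter), downward and beyond the scatter. Compound 4 is thus estimated at 3000 nM, with a range from 1000 nM to 15000 nM.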

Compound 4, concentration for 50% growth inhibition: > 30000 nM
Compound 4: a limit, no number; the forecaster's own chance of this, stated with the estimate: 15%; middle value at least 10-fold (1.00 log units) from the limit.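

In this assay, this position proves narrower than compound 2 alone suggested: with cyclohexyl in place of cyclopentyl on a saturated chain carbon, two bonds along the chain from an oxygen on an aromatic ring, the readable number is lost, an at least 9.0-fold higher number from compound 2 to compound 4 (0.95 log units; beyond the scatter). Going by these compounds alone, a saturated carbon ring on this chain is therefore not enough in itself, and compound 2 remains the only one of the four compounds with a readable number. The result for compound 4 is a limit of the assay, the steps to it from compound 1 and compound 3 cannot be read, and the series now sits largely at that edge: the limit of > 30000 nM in this assay, at which 3 of the 4 values shown sit.

From the compounds shown here alone, it remains open whether the readable number is confined to cyclopentyl or would also appear with cyclobutyl or with a longer chain carrying cyclopentyl. Going by these compounds, the effect of an amine at the end of this chain also remains unknown.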